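The compounds below may be only part of what the source reports. "The series", "measured", "known", "first", "only" and "open" are said of these compounds alone.

Measured compounds in a functional assay on OVCAR-3 cells (Homo sapiens) for cytotoxicity, read by sulforhodamine B assay, with a stated time of 48 h; a higher number here means a weaker inhibitor of growth, a lower number a stronger inhibitor of growth:

compound 1, `ClCc1ccccc1Cn1cnc2ncnc(Cl)c21`: 2040 nM
compound 2, `ClCc1ccc(Cn2cnc3c(Cl)nc(Cl)nc32)cc1`: 2000 nM
compound 3, `ClCc1cccc(Cn2cnc3nc(Cl)nc(Cl)c32)c1`: 1510 nM

Compound 1 has the largest of the three numbers, but its gaps to compound 2 and to compound 3 both lie within the scatter, so the three compounds are not separated by this assay. Among the compounds with values here, no pair differing in one place has been measured, so no single step is known.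

Compound 4, `ClCc1ccccc1Cn1cnc2nc(Cl)nc(Cl)c21`, differs from compound 1 by chloro in place of hydrogen on an aromatic carbon. Compounds 2 and 3 already carry two chloro groups on the shared core and give numbers close to compound 1, so no step beyond the scatter is expected from compound 1 to compound 4 in this assay. Compound 4 is therefore estimated at 1800 nM, range 900 nM to 3600 nM, a step of a 1.1-fold lower number from compound 1 to compound 4 (0.05 log units; within the scatter).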

Compound 4, concentration for 50% growth inhibition: 14100 nM
Compound 4: middle estimate off by 7.8-fold (0.89 log units), on the low side; the whole stated range lies below it.
By their numbers in this assay, from the lowest: compounds 3, 2 and 1 (each within the scatter of the next); then compound 4.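

Within the data shown here, the first step to go beyond the scatter comes from a single added atom: in this assay, chloro in place of hydrogen on the aromatic carbon between two ring nitrogen atoms gives a 6.9-fold higher number from compound 1 to compound 4 (0.84 log units; beyond the scatter). This position is therefore not silent to substitution, and here chloro goes with a weaker inhibitor of growth than hydrogen. Nothing at hand bears on the reason for this step.

Only hydrogen and chloro are shown at this position, so the effect of an amine or a methoxy group there remains open.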